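The source may hold more compounds than are shown below. What is called first, only, known or untested is meant among the compounds shown, and "the series" means these compounds.

Compound 1 `Cc1cc(C)n(-c2ccc(Cl)c(C(=O)NC(=O)Nc3nc4ccc(S(=O)(=O)CCCN5CCN(C)CC5)cc4s3)c2)n1` is the starting point. Going by the values given here, in an assay on HEK293 cells for displacement of a labelled ligand from growth hormone secretagogue receptor type 1 (Homo sapiens), with a stated time of 60 min (on this read-out higher numbers stand for weaker inhibition and lower numbers for stronger inhibition), compound 1 gives 1.3 nM, the higher of the two numbers measured so far. Compound 2 `COc1cc(Cl)c(C(=O)NC(=O)Nc2nc3ccc(S(=O)(=O)CCCN4CCN(C)CC4)cc3s2)cc1-n1cccn1` gives the lower number, 0.62 nM in this assay, and that gap lies beyond the scatter. Compound 3 `CCOc1ccc(Cl)c(C(=O)NC(=O)Nc2nc3ccc(S(=O)(=O)CCCN4CCN(C)CC4)cc3s2)c1` has not been measured; it differs from compound 1 by ethoxy in place of 3,5-dimethyl-1H-pyrazol-1-yl on an aromatic carbon. Among the compounds with values here, no measured pair shows a step of this kind, so the size is uncertain; a modest rise in number is expected, as a 3.1-fold higher number from compound 1 to compound 3 (0.49 log units; beyond the scatter). For compound 3 the expected value in this assay is 4 nM, with a range from 1 nM to 15 nM.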

Compound 3, half-maximal inhibitory concentration: 0.31 nM
Compound 3: the middle estimate sits 13-fold (1.11 log units) above what was measured, and the stated range ends above it.
By their numbers in this assay, from the lowest: compounds 3 and 2 (each within the scatter of the next); then compound 1.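

Ethoxy in place of 3,5-dimethyl-1H-pyrazol-1-yl, on the aromatic carbon para to a chloro group, gives a 4.2-fold lower number from compound 1 to compound 3 (0.62 log units; beyond the scatter), and a lower number here stands for stronger inhibition. This position therefore does not need a ring to keep strong inhibition: a smaller group with no ring does better. Nothing available explains why the number falls. On these data alone, whether a longer propoxy chain or an amine on this carbon would push the number lower stays open. So does whether the step comes from losing the ring or from gaining the ethoxy oxygen.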